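Working notes: chloro in place of ethyl

The source may report more compounds than this note shows. Statements on the series, on what has been measured and on what is new or still open speak of the compounds shown alone.

Values from a functional assay on SMMC-7721 cells (Homo sapiens) for inhibition, read by CCK-8 assay, with a stated time of 72 h, tested at 2 uM (on this read-out higher numbers stand for more inhibition of growth at the one concentration tested and lower numbers for less inhibition of growth), follow
- compound 1 `CCc1ccc(SCc2ccc(/C=C/C(=O)Nc3ccccc3N)cc2)cc1` gives 13.2%
- compound 2 `CCc1ccc(SCc2ccc(C(=O)Nc3ccccc3N)cc2)cc1` gives 25.7%
- compound 3 `COc1ccc(SCc2ccc(C(=O)Nc3ccccc3N)cc2)cc1OC` gives 20.2%

Compound 2 (25.7%) and compound 3 (20.2%) stand within the scatter of each other. Compound 1 shows less inhibition of growth than compound 2 by more than the scatter, with compound 1 at 13.2% on this read-out. Going on to compound 4 `Nc1ccccc1NC(=O)c1ccc(CSc2ccc(Cl)cc2)cc1` puts chloro in place of ethyl on an aromatic carbon and leaves the rest of the structure unchanged. Within the data shown here, no measured pair shows this exchange alone, so the only guide is how close compound 3 (20.2%) stays to compound 2 (25.7%) in this assay here. The step of a number 2.7 percentage points lower from compound 2 to compound 4 (within the scatter) is expected to stay within the scatter, in no set direction. For compound 4 the expected value is 23% within a range of 12% to 37% as estimated.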

Compound 4, percent growth inhibition at one concentration: 2.93%
The estimate for compound 4 lay 20.1 percentage points above the measured number; measured number below the stated range.
By their numbers in this assay, from the lowest: compound 4; then compounds 1, 3 and 2 (each within the scatter of the next, the first and the last beyond it).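

Going from the 4-ethylphenyl to the 4-chlorophenyl group in this assay gives a number 22.8 percentage points lower from compound 2 to compound 4 (beyond the scatter) and so marks this place on the ring, para to a large group, as sensitive to the group it carries. Among these compounds, no earlier pair isolated a single change here. No data at hand account for the step.

As far as these compounds go, whether other groups at this place, such as fluoro, an amine or a longer chain, would fall with chloro or stay with ethyl remains open. Also open, from the compounds shown here alone, is whether chloro has the same effect on the core of compound 1.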